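The source may hold more compounds than are shown below. What is called first, only, known or untested is meant among the compounds shown, and "the series" means these compounds.

Measured so far in an assay on mitochondria (strain BALB/c) for inhibition of glycerol-3-phosphate acyltransferase 1, mitochondrial (Mus musculus), read by scintillation counting, with a stated time of 10 min; a higher number here means a weaker inhibitor, a lower number a stronger inhibitor:
compound 1, `CCCCCCCCS(=O)(=O)Nc1cc(-c2ccc(Cl)cc2)ccc1C(=O)O`, gives 18100 nM;
compound 2, `CCCCCCCCS(=O)(=O)Nc1cc(-c2cccc(F)c2)ccc1C(=O)O`, gives 32600 nM;
compound 3, `CCCCCCCCS(=O)(=O)Nc1ccc(-c2ccccc2Cl)cc1C(=O)O`, gives 14400 nM.

Compound 3 stands close to compound 1: the gap between the two numbers is within the usual scatter of this assay, so they cannot be told apart. Against compound 2 the gap is beyond the scatter. Within the data shown here, the only step measured between two compounds that differ in one place is a 1.8-fold higher number from compound 1 to compound 2 (0.26 log units; within the scatter); it swaps one halogen-bearing phenyl for another and leaves the number within the scatter.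

Compound 4, `CCCCCCCCS(=O)(=O)Nc1ccc(/C=C/c2ccccc2)cc1C(=O)O`, has not yet been measured. It differs from compound 3 by 2-phenylethenyl in place of 2-chlorophenyl on an aromatic carbon. Among the measured compounds shown here, no measured step removes a 2-chlorophenyl or brings in a 2-phenylethenyl, and the step from compound 1 to compound 2 concerns a different kind of exchange, so it gives only weak guidance. The change keeps one six-membered aromatic ring of carbon only and adds one double bond outside aromatic rings, with no change in hydrogen-bond donors or acceptors.

With nothing pointing either way, compound 4 is expected to give about 15000 nM, between 5000 nM and 45000 nM. That amounts to an expected step of a 1.0-fold higher number from compound 3 to compound 4 (0.02 log units; within the scatter), which is no change beyond the scatter.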

Compound 4, half-maximal inhibitory concentration: 16300 nM
The estimate for compound 4 lay 1.1-fold (0.04 log units) below the measured number, within the range that was stated.
By their numbers in this assay, from the lowest: compounds 3, 4, 1 and 2 (each within the scatter of the next, the first and the last beyond it).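

In this assay, 2-phenylethenyl in place of 2-chlorophenyl gives a 1.1-fold higher number from compound 3 to compound 4 (0.05 log units; within the scatter), so the two compounds cannot be told apart. Among these compounds, on this aromatic carbon, meta to a carboxy group and para to a large group, the chlorine can therefore be lost and a double bond outside aromatic rings brought in without a change beyond the scatter, whereas the only earlier step exchanged one halogen-bearing phenyl for another. No independent measurement is available to explain why these two groups give such similar numbers.

On these data alone, it remains open whether this position needs an aromatic ring at all, which a compound with an amine or a plain hexyl chain there could begin to test. The role of the double bond is also unsettled: only a direct comparison with 2-phenylethyl, its saturated counterpart, would show whether that bond matters, and a comparison with the cis form of 2-phenylethenyl would show whether its geometry does.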